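This account rests on a few compounds, and the source may have more. Where it says the series, first, only, none or still open, it means among the compounds named here.

Working notes on the series. Compound 1 `Cc1cc(Cl)ccc1Nc1nc(C(F)(F)F)ccc1C(=O)N/N=C/c1ccc(N(C)C)cc1` gives 66100 nM in a functional assay on NCI60 cells (Homo sapiens) for cytotoxicity, read by sulforhodamine B assay, with a stated time of 48 h; a higher number here means a weaker inhibitor of growth, a lower number a stronger inhibitor of growth. Within the data shown here, compound 2 `Cc1cc(Cl)ccc1Nc1nc(C(F)(F)F)ccc1C(=O)N/N=C/c1cccc(O)c1` gives 11000 nM in this assay, the lowest of the two numbers so far; the only measured step, a 6.0-fold lower number from compound 1 to compound 2 (0.78 log units; beyond the scatter), separates it from compound 1.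

Compound 3 `Cc1cc(Cl)ccc1Nc1nc(C(F)(F)F)ccc1C(=O)N/N=C/c1ccccc1Cl` is the next change to the same position: 2-chlorophenyl in place of 3-hydroxyphenyl on a carbon with a double bond to nitrogen. Among the measured compounds shown here, no measured step matches this change. For the measured compounds named here, the one step on record, from compound 1 to compound 2, concerns a different pair of groups at this position, so it shows only that a swap there can move this assay by a modest amount; it gives no direction for a chlorine in place of a hydroxyl. The estimate for compound 3 is therefore a step close to none beyond the scatter, a 1.4-fold higher number from compound 2 to compound 3 (0.13 log units; within the scatter), with a wide range. Compound 3 is expected near 15000 nM in this assay, between 4000 nM and 55000 nM.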

Compound 3, concentration for total growth inhibition: 5130 nM
Compound 3: the middle estimate sits 2.9-fold (0.47 log units) above what was measured; low and high end bracket the measured number.
By their numbers in this assay, from the lowest: compound 3; then compound 2; then compound 1.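

At the carbon with a double bond to nitrogen, the hydroxyl of 3-hydroxyphenyl is not required for growth inhibition in this assay: 2-chlorophenyl, with 0 hydrogen-bond donors, gives a 2.1-fold lower number from compound 2 to compound 3 (0.33 log units; beyond the scatter) and so takes this position further than compound 2 did. Against 4-(dimethylamino)phenyl the change is larger, a 13-fold lower number from compound 1 to compound 3 (1.11 log units; beyond the scatter), and this is the widest span among the three groups, with compound 3 now lowest of the series. Nothing on hand accounts for this order of the three groups.

Going by these compounds, whether the lower number follows the chlorine itself or its place on the ring stays open, since compound 2 and compound 3 differ in both. Also open is how an amine, a carboxylic acid or a longer chain at this position would read in this assay, as the three groups shown are all substituted phenyls.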